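The source may report more compounds than this note shows. Statements on the series, on what has been measured and on what is new or still open speak of the compounds shown alone.

Measured so far:

- compound 1 `COc1cc(-c2cc(C(=O)O)c3ccccc3n2)ccc1OCC(=O)Nc1ccccc1`: in an ADME assay on HaCaT cells (Homo sapiens) for inhibition (on this read-out higher numbers stand for weaker inhibition and lower numbers for stronger inhibition), compound 1 gives only a limit of the assay, > 300000 nM.
- compound 2 `COc1cc(-c2cc(C(=O)O)c3ccccc3n2)ccc1OCC(=O)Nc1ccc(F)cc1`: compound 2 gives 286000 nM.
- compound 3 `COc1cc(-c2cc(C(=O)O)c3ccccc3n2)ccc1OCC(=O)Nc1cccc(C(F)(F)F)c1`: compound 3 gives 160000 nM.

Compound 3 has the lowest of the two numbers in this assay, but its nearest neighbour is compound 2, and the step of a 1.8-fold lower number from compound 2 to compound 3 (0.25 log units; within the scatter) does not separate them. Compound 1 contributes no number, only (the limit of > 300000 nM in this assay, at which 1 of the 3 values shown sits).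

The next member is compound 4 `COc1cc(-c2cc(C(=O)O)c3ccccc3n2)ccc1OCC(=O)NCc1ccco1`. It differs from compound 3 as follows: (furan-2-yl)methyl in place of 3-(trifluoromethyl)phenyl on an amide-type nitrogen. All measured steps concern substituents on the phenyl carried by the amide nitrogen: an at least 1.0-fold lower number from compound 1 to compound 2 (0.02 log units; that floor lies within the scatter), an at least 1.8-fold lower number from compound 1 to compound 3 (0.27 log units; that floor lies within the scatter) and a 1.8-fold lower number from compound 2 to compound 3 (0.25 log units; within the scatter), none of them beyond the scatter and two of them only floors against a limit. Going by the values given here, no measured step exchanges the aryl group itself for a methylene-linked heteroaryl, so the change in compound 4 is not covered by the evidence. With every measured variation at this position lying within the scatter, no step beyond the scatter is expected in this assay; the estimated step is a 1.6-fold higher number from compound 3 to compound 4 (0.19 log units; within the scatter). Compound 4 is expected to give about 250000 nM, within 100000 nM to 600000 nM, with a fair chance that only a limit is reported.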

Compound 4, half-maximal inhibitory concentration: > 300000 nM
Compound 4 gave a limit, no number; the forecaster's own chance of this, stated with the estimate: 40%; middle value at least 1.2-fold (0.07 log units) away from the limit.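

In this assay compound 4 gives a limit and no number, as compound 1 does: the limit of > 300000 nM in this assay, at which 2 of the 4 values shown sit. Against the two compounds that carry numbers, the exchange gives an at least 1.8-fold higher number from compound 3 to compound 4 (0.27 log units; that floor lies within the scatter) and an at least 1.0-fold higher number from compound 2 to compound 4 (0.02 log units; that floor lies within the scatter); both are floors, so the true size of each stays unknown, and the step between the two limit compounds cannot be read. The new information is that this position has now seen a change of the whole group on the amide-type nitrogen, a (furan-2-yl)methyl with a five-membered aromatic ring in place of a six-membered aromatic ring of carbon only, and not just a change of substituent on the phenyl, and even so no step beyond the scatter can be stated.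

Compound 4 alters the ring and adds a methylene link in one exchange, so a benzyl group on the amide-type nitrogen would be required to tell these two changes apart. From the compounds shown here alone, whether an amine or a longer chain on that nitrogen would give a number clearly beyond the scatter from compound 3 also stays open.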